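Three Limits and a Bicyclic Ketone Amide

A few compounds are considered here, and "the series" means these few. Any claim that something is new, unique, unknown or untested is made for them only; others in the source may bear on it.

Compound 1 `COc1ccc(C#Cc2ccc(C(=O)N3CCCC(OC)C3)cc2)cc1`: in a functional assay on HEK293 cells for negative allosteric modulation of metabotropic glutamate receptor 2 (Rattus norvegicus), read by calcium flux, with a stated time of 2.5 min (a higher number here means a weaker inhibitor, a lower number a stronger inhibitor), compound 1 gives > 30000 nM, a limit of the assay.
Compound 2 `COc1ccc(C#Cc2ccc(C(=O)N3CC[C@@H](O)C3)cc2)cc1`: in this assay compound 2 gives > 30000 nM, a limit of the assay.
Compound 3 `COc1ccc(C#Cc2ccc(C(=O)N3CCC(CO)C3)cc2)cc1`: in this assay compound 3 gives > 30000 nM, a limit of the assay.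

Compound 3 therefore stands nowhere in particular among the numbers shown: it sits at the limit of > 30000 nM in this assay, at which 3 of the 3 values shown sit, together with every other measured value. The steps to it are correspondingly blank. The step that the two limits leave unreadable from compound 1 to compound 3 cannot be sized, nor can a step that the two limits leave unreadable from compound 2 to compound 3, and a step that the two limits leave unreadable from compound 1 to compound 2 is equally unreadable. Compound 4 `COc1ccc(C#Cc2ccc(C(=O)N3CC4CCC(=O)C4C3)cc2)cc1` carries the change (a group of 9 heavy atoms (7 carbon, 1 nitrogen, 1 oxygen; one five-membered non-aromatic ring of carbon only, one five-membered non-aromatic ring with 1 hetero atom) in place of a group of 7 heavy atoms (5 carbon, 1 nitrogen, 1 oxygen; one five-membered non-aromatic ring with 1 hetero atom), on a carbonyl carbon), which removes the 1 hydrogen-bond donor of the 3-(hydroxymethyl)pyrrolidin-1-yl group and brings in a five-membered non-aromatic ring of carbon only fused to the five-membered non-aromatic ring with 1 hetero atom, with 1 double bond outside aromatic rings. No measured step bears on it: all three shown steps are unreadable, so no size or direction can be drawn from them. Compound 4 is expected to sit around 30000 nM, between 3000 nM and 100000 nM, an estimate resting on compound 3 at > 30000 nM. The expected step of a number no higher from compound 3 to compound 4 (the limit leaves the size open) is thus itself only an estimate, most likely ending again at a limit.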

Compound 4, half-maximal inhibitory concentration: > 30000 nM
Compound 4: a limit, no number; the forecaster's own chance of this, stated with the estimate: 65%; the middle value lies on the limit itself.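

In this assay compound 4 gives > 30000 nM, again a limit of the assay and not a number. No step from compound 1, compound 2 or compound 3 to compound 4 can be read, and all four compounds stand at the same place: the limit of > 30000 nM in this assay, at which 4 of the 4 values shown sit.

The compounds shown leave open whether any group on this carbonyl carbon gives a measurable inhibitory value.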